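The compounds below may be only part of what the source reports. "The series", "measured", "known", "first", "only" and "open" are said of these compounds alone.

This study covers two measured compounds and one still to be measured. Among the measured compounds shown here, compound 1 `CC1C(=O)c2nc(CCCN3N=C(c4ccccc4)CCC3=O)[nH]c2N(C)C1=O` and compound 2 `CCCC1C(=O)c2nc(CCCN3N=C(Cl)CCC3=O)[nH]c2N(C)C1=O` share a core but differ in two places, so no single step links them. In an assay on isolated protein for binding affinity to adenosine receptor A1 (Homo sapiens) (a higher number here means a weaker inhibitor, a lower number a stronger inhibitor), compound 1 gives 10800 nM, while compound 2 gives 1200 nM. Compound 2 therefore holds the lowest of the two numbers, and the gap to compound 1 lies beyond the usual scatter, so compound 2 is the stronger binder of the pair.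

Compound 3 `CCCC1C(=O)c2nc(CCCN3N=C(c4ccccc4)CCC3=O)[nH]c2N(C)C1=O` arises from compound 2 by one change: phenyl in place of chloro on a carbon with a double bond to nitrogen. For the measured compounds named here, no measured pair shows this change alone, so its size is not known from these data. Compound 1 carries the phenyl and gives the higher number, but it also differs from compound 3 elsewhere on the core, so the two effects cannot be separated. The expected step from compound 2 to compound 3 in this assay is a 2.5-fold higher number from compound 2 to compound 3 (0.40 log units; beyond the scatter), a moderate rise in the number, meaning weaker binding. Compound 3 is estimated to give 3000 nM, with a likely range from 800 nM to 12000 nM.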

Compound 3, inhibition constant: 810 nM
The estimate for compound 3 lay 3.7-fold (0.57 log units) above the measured number; the range from low to high includes it.
By their numbers in this assay, from the lowest: compounds 3 and 2 (each within the scatter of the next); then compound 1.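

In this assay, phenyl in place of chloro on a carbon with a double bond to nitrogen gives a 1.5-fold lower number from compound 2 to compound 3 (0.17 log units; within the scatter), so at this position a single chlorine and a six-membered aromatic ring of carbon only cannot be told apart, despite the large difference in size between the two groups. The other change, ethyl in place of hydrogen on a saturated chain carbon bound to a saturated ring carbon, gives a 13-fold lower number from compound 1 to compound 3 (1.12 log units; beyond the scatter), so with phenyl present on both sides, the large step in this pair belongs to the chain and phenyl alone does not bring the high number of compound 1. Nothing available here explains why either step has the size it has.

Chloro and phenyl are the only two groups shown at the ring carbon, so it remains open how an amine, a methoxy group or a phenyl ring bearing a fluorine would behave there. Also open, on these data alone, are whether the chain step keeps its size with chloro on the ring instead of phenyl, and what a longer chain would do in the same place.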